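Adding a second chloro to the core of compound 2

A few compounds are considered here, and "the series" means these few. Any claim that something is new, unique, unknown or untested is made for them only; others in the source may bear on it.

Measured compounds:
- compound 1 `ClCc1ccc(Cn2cnc3c(Cl)ncnc32)cc1`: 4780 nM
- compound 2 `ClCc1cccc(Cn2cnc3ncnc(Cl)c32)c1`: 10700 nM
- compound 3 `ClCc1ccc(Cn2cnc3c(Cl)nc(Cl)nc32)cc1`: 10500 nM

In a functional assay on MOLT-4 cells (Homo sapiens) for cytotoxicity, read by sulforhodamine B assay, with a stated time of 48 h (on this read-out higher numbers stand for weaker inhibition of growth and lower numbers for stronger inhibition of growth), compound 2 has the highest number of the three: its gap to compound 3 lies within the scatter, while its gap to compound 1 lies beyond it. Compound 4 `ClCc1cccc(Cn2cnc3nc(Cl)nc(Cl)c32)c1` differs from compound 2 by one change: chloro in place of hydrogen on an aromatic carbon. The same kind of change, a chloro in place of hydrogen on the shared core, has been measured once, and a 2.2-fold higher number from compound 1 to compound 3 (0.34 log units; beyond the scatter). A modest rise of that size is therefore expected here too, in this assay, so compound 4 is estimated at 20000 nM, with a range from 8000 nM to 50000 nM, which would mean an expected step of a 1.9-fold higher number from compound 2 to compound 4 (0.27 log units; within the scatter).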

Compound 4, concentration for 50% growth inhibition: 1040 nM
The estimate for compound 4 lay 19-fold (1.28 log units) above the measured number; the whole stated range lies above it.
By their numbers in this assay, from the lowest: compound 4; then compound 1; then compounds 3 and 2 (each within the scatter of the next).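

In this assay, a chloro in place of hydrogen on the aromatic carbon between two ring nitrogen atoms gives a 10-fold lower number from compound 2 to compound 4 (1.01 log units; beyond the scatter), so a single atom at this position can greatly strengthen growth inhibition. The earlier compounds did not show that the effect of this change depends on the core carrying it, with the number moving in opposite directions on the two cores: the same change on two cores in this assay, a 2.2-fold higher number (0.34 log units; beyond the scatter) from compound 1 to compound 3 and a 10-fold lower number (1.01 log units; beyond the scatter) from compound 2 to compound 4, 23-fold (1.35 log units) apart, beyond the scatter of two such steps

The compounds shown carry only hydrogen or chloro at this position, so the effect of an amine or a methoxy group there remains open. Why the two cores respond differently also remains open.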